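Nitrooxy-bearing benzyl piperidines on a coumarin-type shared core

This account rests on a few compounds, and the source may have more. Where it says the series, first, only, none or still open, it means among the compounds named here.

Measured compounds:
compound 1 `Cc1c(C)c2ccc(OCC3CCN(Cc4cccc(CO)c4)CC3)cc2oc1=O` — 76 nM in an assay for inhibition of Amine oxidase [flavin-containing] B (Homo sapiens), read by fluorescence, using microsomes, with a stated time of 30 min; on this read-out higher numbers stand for weaker inhibition and lower numbers for stronger inhibition
compound 2 `Cc1c(C)c2ccc(OCC3CCN(Cc4cccc(CO[N+](=O)[O-])c4)CC3)cc2oc1=O` — 51 nM in this assay

On the numbers shown, compound 2 gives the lowest number of the two, with compound 1 as the nearest neighbour; the difference a 1.5-fold lower number from compound 1 to compound 2 (0.17 log units; within the scatter) lies within the scatter, so the two cannot be ordered.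

Compound 3 `Cc1c(C)c2ccc(OCC3CCN(Cc4cccc(OCCCO[N+](=O)[O-])c4)CC3)cc2oc1=O` has not yet been measured. It differs from compound 2 by 3-(nitrooxy)propoxy in place of (nitrooxy)methyl on an aromatic carbon. Going by the values given here, the only measured step that bears on this position is a 1.5-fold lower number from compound 1 to compound 2 (0.17 log units; within the scatter), which changed the group on the same aromatic carbon without moving the number beyond the scatter. On this basis no step beyond the scatter is expected for this assay; the estimated step is a 1.2-fold higher number from compound 2 to compound 3 (0.07 log units; within the scatter).

For compound 3 the expected value in this assay is 60 nM, with a likely range from 20 nM to 180 nM.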

Compound 3, half-maximal inhibitory concentration: 550 nM
Compound 3: the middle estimate sits 9.2-fold (0.96 log units) below what was measured; the whole stated range lies below it.
By their numbers in this assay, from the lowest: compounds 2 and 1 (each within the scatter of the next); then compound 3.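

In this assay, this aromatic carbon turns out not to be indifferent to the group it carries: 3-(nitrooxy)propoxy in place of (nitrooxy)methyl gives an 11-fold higher number from compound 2 to compound 3 (1.03 log units; beyond the scatter), and in place of hydroxymethyl it gives a 7.2-fold higher number from compound 1 to compound 3 (0.86 log units; beyond the scatter). A nitrooxy group as such does not go with the higher number, since compound 2 carries one too and stays within the scatter of compound 1, which has none. Nothing available accounts for the size of this step.

The change alters the chain and puts an oxygen on the aromatic carbon in one move, so the compounds shown do not separate the two. Open, going by these compounds, are a 3-(nitrooxy)propyl group, with no such oxygen, and a 3-hydroxypropoxy group, without the nitrooxy end.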